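This account rests on a few compounds, and the source may have more. Where it says the series, first, only, none or still open, it means among the compounds named here.

Measured in an ADME assay on a cell-free system (plasma, Homo sapiens) for metabolic stability, read by LC-MS (a higher number here means that the compound lasts longer, a lower number that the compound disappears faster), all three values being limits:

- Compound 1 `NCc1ccc(C(=O)Nc2ccncc2F)cc1-c1cccc(NC(=O)c2cc(C(=O)O)ccc2F)c1`: > 2 h
- Compound 2 `COCCOC(=O)c1ccc(F)c(C(=O)Nc2cccc(-c3cc(C(=O)Nc4ccncc4F)ccc3CN)c2)c1`: < 0.0834 h
- Compound 3 `CCCOC(=O)c1ccc(NC(=O)c2cccc(-c3cc(C(=O)Nc4ccncc4F)ccc3CN)c2)cc1`: > 2 h

Compound 3 stands at > 2 h, which is a limit and not a number; this is the limit of > 2 h in this assay, at which 2 of the 3 values shown sit. Compound 4 `CC(C)OC(=O)c1cccc(NC(=O)c2cccc(-c3cc(C(=O)Nc4ccncc4F)ccc3CN)c2)c1` has not yet been measured. It differs from compound 3 as follows: 3-(isopropoxycarbonyl)phenyl in place of 4-(propoxycarbonyl)phenyl on an amide-type nitrogen. In words, a 3-(isopropoxycarbonyl)phenyl takes the place of a 4-(propoxycarbonyl)phenyl on an amide-type nitrogen.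

Among the compounds with values here, only one measured step bears on this change, and it bears indirectly: an at least 23-fold lower number from compound 1 to compound 2 (1.37 log units; beyond the scatter). That step is large, but it puts 2-methoxyethyl in place of hydrogen on an oxygen next to a carbonyl group, which is a different change made on a different core. It shows that the half-life in this series can drop sharply. Compound 2 stands at the opposite limit, < 0.0834 h. Compound 3 also carries an ester, so the presence of an ester does not by itself set the outcome, and compound 2 goes against any such rule.

Within the data shown here, with no measured step for this exact swap, no change beyond the scatter is expected, though a modest fall remains possible. The expected step is a step that the limit leaves unreadable from compound 3 to compound 4. For compound 4 the estimated half-life is 3 h, with an expected range from 0.8 h to 8 h.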

Compound 4, half-life: 0.567 h
Estimate against measurement, compound 4: 5.3-fold (0.72 log units) above; measured number outside the range, below it.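

In this assay, within the data shown here, the swap gives an at least 3.5-fold lower number from compound 3 to compound 4 (0.54 log units; beyond the scatter), so rearranging the same atoms on the amide-type nitrogen is enough to shift the half-life beyond the scatter, which the earlier compounds, with their different change on a different core, could not show. Compound 3 stands at a limit of the assay: the limit of > 2 h in this assay, at which 2 of the 4 values shown sit. Compound 4, at 0.567 h, shows that an ester-bearing group at this place can give a half-life that can be read as a number, the only such value among the compounds shown. The ester-bearing compounds therefore now span more than the two limits.

The swap alters two things at once, the numbering of the ester on the phenyl ring and the chain on the ester oxygen, so the compounds shown do not tell which of the two carries the step, since neither 3-(propoxycarbonyl)phenyl nor 4-(isopropoxycarbonyl)phenyl is among them. From the compounds shown here alone, how a tert-butyl ester or an ethyl ester would fare on this amide-type nitrogen also remains open.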